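The compounds below may be only part of what the source reports. "The series", "measured", "known", "first", "only" and "open" are said of these compounds alone.

Measured compounds:
compound 1, `CC(C)N(Cc1cccc(OCCCCCC(=O)O)c1)C(=O)c1ccc(-c2cccc([N+](=O)[O-])c2)cc1`, giving > 26000 nM;
compound 2, `CCOC(=O)CCCCCOc1cccc(CN(C(=O)c2ccccc2)C(C)C)c1`, giving > 26000 nM;
compound 3, `CCOC(=O)CCCCCOc1cccc(CN(C(=O)c2ccc(-c3cccc(C(F)(F)F)c3)cc2)C(C)C)c1`, giving < 1.3 nM.

In an ADME assay on BJ cells (Homo sapiens) for cytotoxicity, read by CellTiter-Glo and resazurin assay, with a stated time of 72 h (a higher number here means that more compound is needed for the effect, a lower number that less compound is needed), compound 3 returns < 1.3 nM, which is a limit of the assay and not a number (the limit of < 1.3 nM in this assay, at which 1 of the 3 values shown sits). Compound 2 also sits at a limit, > 26000 nM. Compound 1 likewise returns a limit, > 26000 nM (the limit of > 26000 nM in this assay, at which 2 of the 3 values shown sit). Compound 3 is therefore the only one of the three whose value lies at the low end of the range the assay can report.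

Among the measured compounds shown here, the single measured step is large: an at least 20000-fold lower number from compound 2 to compound 3 (4.30 log units; beyond the scatter). Compound 4, `CCOC(=O)CCCCCOc1cccc(CN(C(=O)c2ccc(-c3cccc([N+](=O)[O-])c3)cc2)C(C)C)c1`, has not yet been measured in this assay. It differs from compound 3 by nitro in place of trifluoromethyl on an aromatic carbon. For the measured compounds named here, no measured step bears directly on this exchange. The step from compound 2 to compound 3 shows how strongly the group on this aromatic carbon can move the number, and compound 1, which also carries the 3-nitrophenyl group, sits at a limit, though it differs from compound 4 in more than one place.

Compound 4 is therefore expected to lie somewhere between the two limits, estimated at 150 nM, with a range from 2 nM to 12000 nM. The expected step is an at least 110-fold higher number from compound 3 to compound 4 (2.06 log units; beyond the scatter).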

Compound 4, half-maximal effective concentration: < 1.3 nM
Compound 4: a limit, no number; the forecaster's own chance of this, stated with the estimate: 30%; middle value at least 110-fold (2.06 log units) away from the limit.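

In this assay compound 4 sits at the same limit as compound 3, so the step between them cannot be read and nitro and trifluoromethyl on this aromatic carbon cannot be put in order: the limit of < 1.3 nM in this assay, at which 2 of the 4 values shown sit.

Among the compounds shown here, what the earlier compounds did not show is that the large change is not tied to trifluoromethyl: with 3-nitrophenyl in place of hydrogen on an aromatic carbon there is an at least 20000-fold lower number from compound 2 to compound 4 (4.30 log units; beyond the scatter). They also did not show the weight of the ester: with ethyl in place of hydrogen on an oxygen next to a carbonyl group, and the 3-nitrophenyl group kept, there is an at least 20000-fold lower number from compound 1 to compound 4 (4.30 log units; beyond the scatter), so the carboxylic acid and its ethyl ester stand at opposite limits of the read-out.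

As far as these compounds go, how far apart compound 3 and compound 4 truly lie stays unknown, since both carry a limit and not a number. Also open, from the compounds shown here alone, is whether an amine or a methoxy group on this aromatic carbon would reach the same low limit, and whether the carboxylic acid carrying 3-(trifluoromethyl)phenyl would stay at the high limit, as compound 1 does.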